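This account rests on a few compounds, and the source may have more. Where it says the series, first, only, none or still open, it means among the compounds named here.

Measured compounds:
compound 1, `O=C(O)Cc1sc(C2COc3ccccc3O2)nc1-c1ccc(Cl)cc1` — 500 nM
compound 2, `O=C(O)Cc1sc(C(Cc2ccccc2)c2ccccc2)nc1-c1ccc(Cl)cc1` — 56 nM
compound 3, `O=C(O)Cc1sc(C(c2ccc(F)cc2)c2ccc(F)cc2)nc1-c1ccc(Cl)cc1` — 9.7 nM

All three share the same core and were tested in an in vitro assay on HEK385-7 cells for displacement of a labelled ligand from prostaglandin D2 receptor 2 (Homo sapiens); a lower number here means a stronger inhibitor, a higher number a weaker inhibitor. On these numbers compound 2 stands second highest of the three: compound 3 gives a lower number, and compound 1 a higher one, and both gaps lie beyond the usual scatter of repeated measurements.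

The next compound, compound 4 with the structure `COc1ccc(C(c2ccccc2)c2nc(-c3ccc(Cl)cc3)c(CC(=O)O)s2)cc1`, has not yet been measured in this assay. It differs from compound 2 in one place: 4-methoxyphenyl in place of benzyl on a saturated chain carbon bound to two aromatic carbons. After the change, the saturated chain carbon carries two aromatic rings directly, as it does in compound 3, whereas in compound 2 one of the two groups on that carbon is a benzyl.

Among the measured compounds shown here, no measured pair shows exactly this change, so the expected step rests on the comparison of compound 2 and compound 3 alone. Since compound 3, with two aromatic rings on that carbon, gives 9.7 nM, a move in the same direction is expected for compound 4: the number is expected to fall by a 3.7-fold lower number from compound 2 to compound 4 (0.57 log units; beyond the scatter), beyond the scatter. The estimate for compound 4 in this assay is 15 nM, within a range from 5 nM to 50 nM.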

Compound 4, half-maximal inhibitory concentration: 8.4 nM
Compound 4: the middle estimate sits 1.8-fold (0.25 log units) above what was measured; low and high end bracket the measured number.
By their numbers in this assay, from the lowest: compounds 4 and 3 (each within the scatter of the next); then compound 2; then compound 1.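

In this assay, putting 4-methoxyphenyl in place of benzyl on a saturated chain carbon bound to two aromatic carbons gives a 6.7-fold lower number from compound 2 to compound 4 (0.82 log units; beyond the scatter), so this position responds clearly to a single change. This is the only comparison shown in which one group at this position is exchanged while the rest of the molecule stays the same, and it shows that a benzyl is not needed there for binding in the nanomolar range. Among the compounds shown here, the single swap alters two things at once, however: an aromatic ring now sits directly on that carbon, and the entering group brings an oxygen and a hydrogen-bond acceptor that benzyl lacks, and no measurement is available to explain the gain.

Going by these compounds, it remains open whether the ring's direct attachment or the methoxy group accounts for the step, and a plain phenyl at this position would separate the two. A 4-hydroxyphenyl or a 2-phenylethyl group there would further show how much the oxygen substituent and the length of the link matter.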